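The source may hold more compounds than are shown below. What is called first, only, known or untested is meant among the compounds shown, and "the series" means these compounds.

In a functional assay on MCF7 cells (Homo sapiens) for inhibition, read by MTT assay, with a stated time of 48 h (a lower number here means a stronger inhibitor, a higher number a weaker inhibitor), compound 3 (`O=C(CCCCCCNC(=O)Cn1cnc2c(Nc3ccccc3)ncnc21)NO`) gives > 50000 nM and this is a limit of the assay, not a number. Compound 1 (`O=C(CCCCCNC(=O)Cn1cnc2c(Nc3ccccc3)ncnc21)NO`) gives > 50000 nM and this too is a limit. Compound 2 (`O=C(CCCCNC(=O)Cn1cnc2c(Nc3ccccc3)nc(Nc3ccccc3)nc21)NO`) gives > 50000 nM and this is again a limit. Compound 3 therefore stands with the other two at the limit of > 50000 nM in this assay, at which 3 of the 3 values shown sit, and no order among the three can be read.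

Compound 4 (`O=C(CCCCNC(=O)Cn1cnc2c(Nc3ccccc3)ncnc21)NO`) has not yet been measured. Its difference from compound 3 is hydroxycarbamoyl in place of 2-(hydroxycarbamoyl)ethyl on a saturated chain carbon, four bonds along the chain from an amide-type nitrogen and the core stays the same, so only the chain carrying the hydroxycarbamoyl end becomes shorter. Among the measured compounds shown here, the one measured step that alters this chain is a step that the two limits leave unreadable from compound 1 to compound 3 and it supplies no size to carry over, as neither of its ends is a number.

Compound 4 is expected to remain in the same region because the limit of > 50000 nM in this assay, at which 3 of the 3 values shown sit, holds for every neighbour measured so far. The estimated step is a number no higher from compound 3 to compound 4 (the limit leaves the size open) and no change beyond the scatter is expected in either direction. For compound 4 the expected value is 50000 nM with an estimated range from 20000 nM to 100000 nM and quite possibly only a limit will be reported.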

Compound 4, half-maximal inhibitory concentration: > 50000 nM
Compound 4: a limit, no number; the forecaster's own chance of this, stated with the estimate: 85%; the middle value lies on the limit itself.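

Compound 4 gives only a limit, as do compound 1, compound 2 and compound 3, so no step among these compounds can be read from this assay: the limit of > 50000 nM in this assay, at which 4 of the 4 values shown sit. The compounds shown leave open how strong any of them actually is, and whether the length of the chain or the anilino group makes any difference.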